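The compounds below may be only part of what the source reports. "The series", "measured", "known", "first", "only" and "open" are said of these compounds alone.

For the measured compounds named here, compound 3 `O=C1O[C@H]([C@@H](O)Cn2cc(C3CC3)nn2)C(OCc2ccccc2)=C1OCc1ccccc1` is one of three compounds measured in a functional assay on HeLa cells (Homo sapiens) for antiproliferative activity, read by MTT assay, with a stated time of 72 h; a higher number here means a weaker inhibitor, a lower number a stronger inhibitor. In this assay compound 3 gives 26500 nM. Compound 2 `Cc1ccc(-c2cn(C[C@H](O)[C@H]3OC(=O)C(OCc4ccccc4)=C3OCc3ccccc3)nn2)cc1` gives 25500 nM in this assay, and the two numbers sit within the scatter of each other, so neither can be set above the other. Compound 1 `COc1ccccc1-c1cn(C[C@H](O)[C@H]2OC(=O)C(OCc3ccccc3)=C2OCc2ccccc2)nn1` gives only a limit of the assay, > 100000 nM in this assay. The measured steps run an at least 3.9-fold lower number from compound 1 to compound 2 (0.59 log units; beyond the scatter) and an at least 3.7-fold lower number from compound 1 to compound 3 (0.57 log units; beyond the scatter), both beyond the scatter, whereas a 1.0-fold higher number from compound 2 to compound 3 (0.02 log units; within the scatter) stays within it.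

Compound 4 `O=C1O[C@H]([C@@H](O)Cn2ccnn2)C(OCc2ccccc2)=C1OCc1ccccc1` is not yet measured. It differs from compound 3 by hydrogen in place of cyclopropyl on an aromatic carbon. Going by the values given here, none of the measured steps removes a group from that aromatic carbon altogether; the only step that ends at cyclopropyl, a 1.0-fold higher number from compound 2 to compound 3 (0.02 log units; within the scatter), shows that swapping one group for another on that carbon left the number within the scatter, while the steps leaving 2-methoxyphenyl were larger. On this slim basis the step of a 1.5-fold higher number from compound 3 to compound 4 (0.18 log units; within the scatter) is expected to be small, with the number more likely to rise than to fall, though a change within the scatter is also possible. Compound 4 is therefore estimated at 40000 nM in this assay, within a range of 15000 nM to 100000 nM.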

Compound 4, half-maximal inhibitory concentration: > 100000 nM
Compound 4: only a limit was reported (the forecaster's own chance of this, stated with the estimate: 25%); middle value at least 2.5-fold (0.39 log units) away from the limit.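

For the compounds shown here, compound 4 is the only compound here with hydrogen on this aromatic carbon of the five-membered aromatic ring, and the result shows that losing the group altogether matters more than exchanging cyclopropyl for 4-methylphenyl, which left the number within the scatter. Taking away cyclopropyl gives an at least 3.7-fold higher number from compound 3 to compound 4 (0.57 log units; beyond the scatter), and taking away 4-methylphenyl gives an at least 3.9-fold higher number from compound 2 to compound 4 (0.59 log units; beyond the scatter), so in this assay both groups stand apart from hydrogen, each by a step beyond the scatter. A group on this carbon is still not enough by itself, as compound 1, with 2-methoxyphenyl, goes against any such rule, and the step between compound 1 and compound 4 cannot be read because both values are limits: the limit of > 100000 nM in this assay, at which 2 of the 4 values shown sit.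

Going by these compounds, what remains open is whether a methyl group or a longer chain such as n-butyl on this carbon would read like cyclopropyl and 4-methylphenyl or like hydrogen. The compounds shown also leave open where an amine, a hydroxymethyl group or a carboxylic acid in this place would fall in the same assay.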